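A few compounds are considered here, and "the series" means these few. Any claim that something is new, unique, unknown or untested is made for them only; others in the source may bear on it.

Working notes on the series. Among the measured compounds shown here, compound 1 `CCOc1ccc(-c2nc(NS(=O)(=O)c3ccc(OC)c(F)c3)sc2-c2cc(OC)c(OC)c(OC)c2)cc1` and compound 2 `C=CCN(CC=C)c1nc(-c2ccc(OCC)cc2)c(-c2cc(OC)c(OC)c(OC)c2)s1` are the two compounds measured so far. In a functional assay on HCT-116 cells (Homo sapiens) for antiproliferative activity, read by MTT assay, with a stated time of 48 h (on this read-out lower numbers stand for stronger inhibition and higher numbers for weaker inhibition), compound 1 gives > 5000 nM, a limit of the assay rather than a number. In this assay compound 2 gives > 5000 nM, likewise only a limit. On the numbers shown compound 2 therefore cannot be placed against compound 1: both values sit at the limit of > 5000 nM in this assay, at which 2 of the 2 values shown sit, and no order between them can be read.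

Compound 3 `CCCN(CCC)c1nc(-c2ccc(OCC)cc2)c(-c2cc(OC)c(OC)c(OC)c2)s1` is not yet measured and differs from compound 2 in one place: dipropylamino in place of diallylamino on an aromatic carbon. For the measured compounds named here, no step between measured compounds exists, so no measured step size can be drawn on. Since compound 2 in this assay gives > 5000 nM, a limit, the expectation for compound 3 is a step that the limit leaves unreadable from compound 2 to compound 3, which is no change beyond the scatter. Compound 3 is accordingly estimated at 8000 nM, with a range from 3000 nM to 30000 nM, and most likely reported only as a limit.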

Compound 3, half-maximal inhibitory concentration: > 5000 nM
Compound 3 was reported as a limit; the forecaster's own chance of this, stated with the estimate: 75%; the middle value does not contradict the limit.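

In this assay compound 3 gives > 5000 nM, a limit and not a number. The step between compound 2 and compound 3 therefore cannot be read: the limit of > 5000 nM in this assay, at which 3 of the 3 values shown sit.

The compounds shown leave open how dipropylamino and diallylamino compare, and which structural features would give a value that can be read as a number.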